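From ethylamino to propylamino on the shared core

This account rests on a few compounds, and the source may have more. Where it says the series, first, only, none or still open, it means among the compounds named here.

In a functional assay on BT-483 cells (Homo sapiens) for cytotoxicity, read by MTT assay, with a stated time of 24 h (on this read-out higher numbers stand for weaker inhibition and lower numbers for stronger inhibition), compound 1 `CCNc1cc(-c2ccc(NC(=O)Nc3ccc(OC)cc3)cc2C(F)(F)F)ccn1` gives 17600 nM and compound 2 `CCNc1cc(-c2ccc(NC(=O)Nc3ccc(C(F)(F)F)cc3)cc2C(F)(F)F)ccn1` gives 16400 nM. Among the measured compounds shown here, compound 2 therefore stands level with compound 1, since the only measured step, a 1.1-fold lower number from compound 1 to compound 2 (0.03 log units; within the scatter), lies within the scatter. Compound 3 `CCCNc1cc(-c2ccc(NC(=O)Nc3ccc(C(F)(F)F)cc3)cc2C(F)(F)F)ccn1` differs from compound 2 by methyl in place of hydrogen on a saturated chain carbon, two bonds along the chain from a nitrogen on an aromatic ring, which reads as ethylamino to propylamino. For the measured compounds named here, that measured step changed another part of the molecule, so no measured step tests this chain directly. The expected change is only a 1.1-fold lower number from compound 2 to compound 3 (0.04 log units; within the scatter), with no shift beyond the scatter in either direction. Compound 3 is estimated at 15000 nM, within a range of 7000 nM to 30000 nM.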

Compound 3, half-maximal inhibitory concentration: 18800 nM
Estimate against measurement, compound 3: 1.3-fold (0.10 log units) below, and the stated range covers the measured number.
By their numbers in this assay, from the lowest: compounds 2, 1 and 3 (each within the scatter of the next).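

In this assay the change from ethylamino to propylamino gives a 1.1-fold higher number from compound 2 to compound 3 (0.06 log units; within the scatter), so compound 3 stands level with compound 2. Among the compounds shown here, this is the first direct test of the chain on the shared core, and one added methyl at this place does not move the number beyond the scatter. Nothing available accounts for this level result. As far as these compounds go, whether butylamino, isopropylamino or a cyclic amine in place of propylamino would shift the number beyond the scatter stays open. So does whether a hydroxyl or a carboxylic acid at the chain end would.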